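A few compounds are considered here, and "the series" means these few. Any claim that something is new, unique, unknown or untested is made for them only; others in the source may bear on it.

In an ADME assay on microsomes from liver (Homo sapiens) for metabolic stability, with a stated time of 30 min, tested at 1 uM (on this read-out lower numbers stand for a less stable compound and higher numbers for a more stable compound), compound 1 `COc1cc(C)c(S(=O)(=O)N(C)CCOCC(=O)N2CCC(C3CCN(C)CC3)CC2)c(C)c1` gives 23%. Compound 2 `Cc1c(Cl)ccc(S(=O)(=O)N(C)CCCCC(=O)N(C)Cc2ccc(C3=NCCN3)cc2)c1Cl` gives 0%. Compound 1 therefore holds the higher of the two numbers, and the gap between them lies beyond the usual scatter. The two compounds differ in more than one place, so this gap cannot be tied to any single structural change.

Compound 3 `COc1cc(C)c(S(=O)(=O)N(C)CCOCC(=O)N2CCC(C3CCN(C(C)C)CC3)CC2)c(C)c1` keeps the core of compound 1 and changes one place: isopropyl in place of methyl on an amine nitrogen in a ring. This is isopropyl in place of methyl on an amine nitrogen in a ring, or 1-methylpiperidin-4-yl to 1-isopropylpiperidin-4-yl. Among the compounds with values here, no measured pair shows this change, so the data give neither a size nor a direction for it. The closest reference is compound 1 at 23%, and no shift beyond the scatter is expected in this assay. The estimated a number 3 percentage points lower from compound 1 to compound 3 (within the scatter) is therefore small, with wide uncertainty on either side. For compound 3 the expected value is 20%, with an estimated range of 6% to 40%.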

Compound 3, percent of the compound remaining: 23%
Compound 3: the middle estimate sits 3 percentage points below what was measured, within the range that was stated.
By their numbers in this assay, from the lowest: compound 2; then compounds 1 and 3 (each within the scatter of the next).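

In this assay, within the data shown here, isopropyl in place of methyl on the amine nitrogen in the ring gives no change at the digits printed from compound 1 to compound 3 (within the scatter), and this is the first step that can be read at a single place. It shows that, on the core of compound 1, the substituent at this position, three ring bonds from the ring atom that bears a large group, can go from methyl to isopropyl with no difference in this read-out beyond the scatter, a finding that the earlier gap between two compounds differing in more than one place could not give. Nothing at hand explains why this step leaves the number where it is.

What the compounds shown leave open is whether this position would read the same with a hydrogen on the nitrogen, with cyclopropyl, or with a longer chain such as n-butyl or 2-hydroxyethyl. This single step also says nothing about the same exchange on another core, and it does not show which part of the shared core sets the value in this read-out.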